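Furan acrylamides: para substituent swap on the phenyl ring

The source may hold more compounds than are shown below. What is called first, only, known or untested is meant among the compounds shown, and "the series" means these compounds.

Measured compounds:
compound 1 `C/C(=C\c1cc(-c2ccc(C)nc2)co1)C(N)=O` — > 50000 nM
compound 2 `C/C(=C\c1ccc(-c2ccc(C)cc2)o1)C(N)=O` — 4590 nM

Among the measured compounds shown here, in a functional assay on HeLa cells (Homo sapiens) for cytotoxicity, read by CCK-8 assay, with a stated time of 24 h (a higher number here means a weaker inhibitor, a lower number a stronger inhibitor), compound 2 gives 4590 nM and is the only compound with a numerical value. Compound 1 returns a limit of the assay, > 50000 nM; this is a limit and not a number, so no distance between compound 1 and compound 2 can be stated, and the limit is noted as such (the limit of > 50000 nM in this assay, at which 1 of the 2 values shown sits). For the measured compounds named here, no step between two measured compounds is available for this assay.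

The next compound, compound 3 `C/C(=C\c1ccc(-c2ccc(F)cc2)o1)C(N)=O`, is made from compound 2 by fluoro in place of methyl on an aromatic carbon. Both groups are of similar size, and the change keeps donor and acceptor count unchanged. Going by the values given here, with no comparable step measured in this assay, the expectation is a shift of no more than the usual scatter, leaning slightly toward weaker inhibition: the expected step is a 1.3-fold higher number from compound 2 to compound 3 (0.12 log units; within the scatter). Compound 3 is therefore estimated at 6000 nM in this assay, with a range from 2500 nM to 15000 nM.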

Compound 3, half-maximal inhibitory concentration: 2030 nM
The estimate for compound 3 lay 3.0-fold (0.47 log units) above the measured number, and the stated range ends above it.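

In this assay, among the compounds shown here, the exchange of methyl for fluoro on the aromatic carbon para to a large group gives a 2.3-fold lower number from compound 2 to compound 3 (0.35 log units; beyond the scatter) and so provides the first readable step. This carbon therefore responds to substitution: a swap of one heavy atom for another, with no change in the counted hydrogen-bond donors or acceptors and no net charge on either group, moves the number beyond the scatter. Compound 1 has > 50000 nM in this assay and this is a limit and not a number, so steps involving it cannot be read.

Still open, going by these compounds, is whether the trend continues with other groups at this carbon, such as chloro, methoxy, an amine or a carboxylic acid, and whether the same exchange gives a similar step on the core of compound 1. Since a single step rests on one pair of compounds, nothing measured here indicates why the number moves.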